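The source may hold more compounds than are shown below. What is called first, only, known or untested is meant among the compounds shown, and "the series" means these compounds.

In a functional assay on HepG2 cells (Homo sapiens) for cytotoxicity, read by MTT assay, with a stated time of 72 h (on this read-out higher numbers stand for weaker inhibition and lower numbers for stronger inhibition), compound 1 `CN1CCN(c2ccc(Nc3ncc4nc(Nc5ccccc5)n(C5CCCCC5)c4n3)cc2)CC1` is reported only as a limit, > 5000 nM. Compound 2 `CN1CCN(c2ccc(Nc3ncc4nc(Nc5ccccc5)n(-c5ccccc5)c4n3)cc2)CC1` is likewise reported only as a limit, > 5000 nM, so it has no number of its own. The two compounds share (the limit of > 5000 nM in this assay, at which 2 of the 2 values shown sit). For the measured compounds named here, the one measured step is a step that the two limits leave unreadable from compound 1 to compound 2, where phenyl takes the place of cyclohexyl on an aromatic nitrogen. Compound 3 `Cc1cc(C)cc(-n2c(Nc3ccccc3)nc3cnc(Nc4ccc(N5CCN(C)CC5)cc4)nc32)c1` changes that group again, with 3,5-dimethylphenyl in place of phenyl on an aromatic nitrogen. No size can be carried over from a step that the two limits leave unreadable from compound 1 to compound 2, so no shift beyond the scatter is expected in this assay, and a further limit would be no surprise. The expected step is a step that the limit leaves unreadable from compound 2 to compound 3. Compound 3 is estimated at 7000 nM, with an expected range from 2500 nM to 20000 nM.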

Compound 3, half-maximal inhibitory concentration: > 5000 nM
Compound 3: a limit, no number; the forecaster's own chance of this, stated with the estimate: 75%; the middle value is on the limit's open side.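

For the compounds shown here, no step among compound 1, compound 2 and compound 3 can be read, because all three are reported only as limits: the limit of > 5000 nM in this assay, at which 3 of the 3 values shown sit. The compounds shown leave open what value any of them has in this assay, and whether cyclohexyl, phenyl and 3,5-dimethylphenyl on the aromatic nitrogen differ there at all.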